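The source may hold more compounds than are shown below. What is called first, only, known or untested is meant among the compounds shown, and "the series" means these compounds.

Measured so far in a functional assay on COR-L23 cells (Homo sapiens) for antiproliferative activity, read by CellTiter-Glo, with a stated time of 4 days (on this read-out higher numbers stand for weaker inhibition and lower numbers for stronger inhibition), as follows
- compound 1 `O=C(NCc1cccnc1)Nc1ccc(CN2C(=O)c3ccccc3C2=O)cc1` gives "not determined" (no result reported) (no result reported)
- compound 2 `C[C@H](NC(=O)C1CCOCC1)c1ccc(NC(=O)[C@H]2C[C@@H]2c2cccnc2)cc1` gives 7 nM (the only number)

Among the compounds with values here, compound 2 holds the only number, so it cannot yet be ranked against anything. Compound 3 `C[C@H](NC(=O)c1ccc(C#N)cc1)c1ccc(NC(=O)[C@H]2C[C@@H]2c2cccnc2)cc1` carries 4-cyanophenyl in place of oxan-4-yl on a carbonyl carbon. Within the data shown here, no measured step covers this change, so no step beyond the scatter is expected in this assay, in either direction. The expected change is a 1.1-fold higher number from compound 2 to compound 3 (0.06 log units; within the scatter) in this estimate. For compound 3 the estimated value is 8 nM with an expected range of 2 nM to 30 nM in this read-out.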

Compound 3, half-maximal inhibitory concentration: 19 nM
Estimate against measurement, compound 3: 2.4-fold (0.38 log units) below; low and high end bracket the measured number.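

In this assay the place on the carbonyl carbon accepts 4-cyanophenyl in place of oxan-4-yl at a modest cost (a 2.7-fold higher number from compound 2 to compound 3 (0.43 log units; beyond the scatter)), so a non-aromatic ring is not required here and an aromatic ring of carbon only keeps activity. No measurement at hand accounts for this step.

On these data alone, it remains open whether the step follows the nitrile or the aromatic ring itself, which plain phenyl on this carbonyl would separate. How an amine such as piperidin-4-yl or a carboxylic acid would read here is also unknown.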